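The source may hold more compounds than are shown below. What is called first, only, known or untested is meant among the compounds shown, and "the series" means these compounds.

Three compounds have so far gone into a functional assay on NCI-H1993 cells (Homo sapiens) for inhibition, read by CCK-8 assay, with a stated time of 72 h (a higher number here means a weaker inhibitor, a lower number a stronger inhibitor), and only one of them has a number. Compound 1 `CCC(c1ccc2ncccc2c1F)n1cnc2ncc(-c3ccncc3)nc21` is recorded as "not determined" (no result reported) and compound 2 `Cc1cc2ncccc2cc1C(C)n1cnc2ncc(-c3ccncc3)nc21` as "not determined" (no result reported) so neither offers a comparison. Compound 3 `CC(NC/N=C/c1ccnn1C)c1ccc2ncccc2c1` gives 3290 nM in this assay and, as the only figure available, it cannot yet be ranked against anything.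

Still unmeasured is compound 4 `CC(NC/N=C/c1cnn(CCO)c1)c1ccc2ncccc2c1`, which differs from compound 3 in one place: 1-(2-hydroxyethyl)-1H-pyrazol-4-yl in place of 1-methyl-1H-pyrazol-5-yl on a carbon with a double bond to nitrogen. Among the compounds with values here, no measured pair shows what such a swap does, so any forecast here is loose and the range has to be wide. The estimate is a modest move toward stronger inhibition, only a little beyond the usual scatter of repeat measurements (a 2.2-fold lower number from compound 3 to compound 4 (0.34 log units; beyond the scatter)). For compound 4 the expected value is 1500 nM (estimated range 300 nM to 6000 nM).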

Compound 4, half-maximal inhibitory concentration: 148 nM
Beside the measured number, compound 4's estimate is 10-fold (1.01 log units) above it; the measured number lies below the stated range.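

Within the data shown here, replacing 1-methyl-1H-pyrazol-5-yl with 1-(2-hydroxyethyl)-1H-pyrazol-4-yl on a carbon with a double bond to nitrogen produces a 22-fold lower number from compound 3 to compound 4 (1.35 log units; beyond the scatter) in this assay and so gives the first sign that the group at this place can strongly change the result. The swap makes two changes at once, since the ring is attached through a different carbon and its methyl gives way to a 2-hydroxyethyl chain that brings a hydrogen-bond donor. Nothing measured here explains a gain of this size.

These two compounds cannot say which part of the swap matters, and a 1-methyl-1H-pyrazol-4-yl group at this place would separate the two parts. Also open, going by these compounds, is whether the hydroxyl itself counts, which a 2-methoxyethyl chain or a longer 3-hydroxypropyl chain could test.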